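Lengthening the linker chain in a cyanoguanidine series

The source may report more compounds than this note shows. Statements on the series, on what has been measured and on what is new or still open speak of the compounds shown alone.

Measured so far:
compound 1, `N#C/N=C1\N(CCCCCCCOc2ccc(Cl)cc2)C(=O)CN1c1ccncc1`: 815 nM
compound 2, `N#C/N=C1\N(CCCCCOc2ccc(Cl)cc2)C(=O)CCN1c1ccncc1`: 5460 nM

In a functional assay on MCF7 cells (Homo sapiens) for cytotoxicity (a higher number here means a weaker inhibitor, a lower number a stronger inhibitor), compound 2 gives 5460 nM, the highest of the two numbers, while compound 1 gives 815 nM, a gap that lies beyond the scatter. Compound 3, `N#C/N=C1\N(CCCCCCCOc2ccc(Cl)cc2)C(=O)CCN1c1ccncc1`, has not been measured. It differs from compound 2 in one place: 2-(4-chlorophenoxy)ethyl in place of 4-chlorophenoxy on a saturated chain carbon, five bonds along the chain from an amide-type nitrogen in a ring. The chain between the shared core and the chlorinated ring thus grows by two carbons. Within the data shown here, no measured pair shows this change alone, so the size of the step is uncertain. Compound 1 shows that lower numbers are reached within this set, so a step downward from compound 2 of a 3.6-fold lower number from compound 2 to compound 3 (0.56 log units; beyond the scatter) is expected. For compound 3 the estimate in this assay is 1500 nM, with a range from 500 nM to 5000 nM.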

Compound 3, half-maximal inhibitory concentration: 6840 nM
The estimate for compound 3 lay 4.6-fold (0.66 log units) below the measured number; measured number outside the range, above it.
By their numbers in this assay, from the lowest: compound 1; then compounds 2 and 3 (each within the scatter of the next).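

In this assay, putting 2-(4-chlorophenoxy)ethyl in place of 4-chlorophenoxy on a saturated chain carbon, five bonds along the chain from an amide-type nitrogen in a ring, gives a 1.3-fold higher number from compound 2 to compound 3 (0.10 log units; within the scatter), so at this position the two extra chain carbons leave the two compounds indistinguishable. Compound 3 carries the same chain as compound 1, yet compound 3 gives 6840 nM while compound 1 gives 815 nM, so the chain alone does not bring the number of compound 1 to the shared core of compounds 2 and 3. Nothing measured here explains why compounds 2 and 3 read alike. Still open, going by these compounds, is whether a longer chain would stay within the scatter of these two compounds. Also open, on these data alone, is what an amine in the chain would do.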